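The compounds below may be only part of what the source reports. "The series", "measured", "known", "first", "only" and "open" are said of these compounds alone.

In a functional assay on DU-145 cells (Homo sapiens) for inhibition, read by trypan blue exclusion, with a stated time of 96 h (a higher number here means a weaker inhibitor of growth, a lower number a stronger inhibitor of growth), compound 3 `O=C(/C(=C\c1ccc(O)c([N+](=O)[O-])c1)Sc1c(F)c(F)c(F)c(F)c1F)c1ccc(Br)cc1` gives 10000 nM. For the measured compounds named here, that is level with compound 2 `O=C(/C(=C\c1ccc(Cl)c([N+](=O)[O-])c1)Sc1ccc(Br)cc1)c1ccc(Br)cc1`, which gives 10000 nM, and together they hold the highest number so far. Compound 1 `COc1cc(/C=C(/Sc2ccc(Br)cc2)C(=O)c2ccc(Br)cc2)ccc1O` gives 1000 nM, a clearly lower number. Compound 4 `O=C(/C(=C\c1ccc(O)c([N+](=O)[O-])c1)Sc1ccc(Br)cc1)c1ccc(Br)cc1` is not yet measured. It differs from compound 3 by 4-bromophenyl in place of 2,3,4,5,6-pentafluorophenyl on a sulfur, with 4-bromophenyl in place of 2,3,4,5,6-pentafluorophenyl on a sulfur. That 4-bromophenyl is already present in compound 1, at 1000 nM, and in compound 2, at 10000 nM, though both also differ elsewhere, so it offers only a loose guide. A modest drop is expected, and the estimated step is a 3.3-fold lower number from compound 3 to compound 4 (0.52 log units; beyond the scatter). The expected value for compound 4 is 3000 nM, within an estimated range of 700 nM to 10000 nM.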

Compound 4, concentration for 50% growth inhibition: 1000 nM
Estimate against measurement, compound 4: 3.0-fold (0.48 log units) above; measured number inside the range.
By their numbers in this assay, from the lowest: compounds 1 and 4 (each within the scatter of the next); then compounds 2 and 3 (each within the scatter of the next).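

Two single changes each matter here: in this assay 4-bromophenyl in place of 2,3,4,5,6-pentafluorophenyl on a sulfur brings a 10-fold lower number from compound 3 to compound 4 (1.00 log units; beyond the scatter) and hydroxy in place of chloro on an aromatic carbon brings a 10-fold lower number from compound 2 to compound 4 (1.00 log units; beyond the scatter). Nitro in place of methoxy on an aromatic carbon, by contrast, brings no change at the digits printed from compound 1 to compound 4 (within the scatter) and so separates nothing in this pair. Nothing measured here explains these steps. Still open, on these data alone, is whether an unsubstituted phenyl or a 4-chlorophenyl on the sulfur would match 4-bromophenyl, and whether an amine could stand in for the hydroxy.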